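A few compounds are considered here, and "the series" means these few. Any claim that something is new, unique, unknown or untested is made for them only; others in the source may bear on it.

Measured compounds and their numbers in an assay for inhibition of Amine oxidase [flavin-containing] B (Bos taurus), read by fluorescence, with a stated time of 60 min; a higher number here means a weaker inhibitor, a lower number a stronger inhibitor:
- compound 1 `Cc1ccc(C(=O)NNC(=O)Cn2c(=O)c(Cc3ccccc3)nc3ccccc32)cc1`: 680000 nM
- compound 2 `O=C(Cn1c(=O)c(Cc2ccccc2)nc2ccccc21)N/N=C/c1ccc(Br)cc1`: 26000 nM
- compound 3 `O=C(Cn1c(=O)c(Cc2ccccc2)nc2ccccc21)N/N=C/c1ccc([N+](=O)[O-])cc1`: 84000 nM

Compound 3 holds the second highest number of the three. Its nearest neighbour is compound 2, and the step of a 3.2-fold higher number from compound 2 to compound 3 (0.51 log units; beyond the scatter) separates them; compound 1 is furthest away, with the step of an 8.1-fold lower number from compound 1 to compound 3 (0.91 log units; beyond the scatter) lying between them. Both hydrazone compounds, 2 and 3, sit well below the diacylhydrazide compound 1, as the steps of a 26-fold lower number from compound 1 to compound 2 (1.42 log units; beyond the scatter) and an 8.1-fold lower number from compound 1 to compound 3 (0.91 log units; beyond the scatter) show.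

Compound 4 `O=C(Cn1c(=O)c(Cc2ccccc2)nc2ccccc21)N/N=C1/C(=O)Nc2ccccc21` is not yet measured. It differs from compound 3 in this way: a group of 11 heavy atoms (8 carbon, 2 nitrogen, 1 oxygen; one five-membered non-aromatic ring with 1 hetero atom, one six-membered aromatic ring of carbon only) in place of a group of 11 heavy atoms (7 carbon, 2 nitrogen, 2 oxygen; one six-membered aromatic ring of carbon only), on an amide-type nitrogen. The hydrazone linkage of compounds 2 and 3 is kept in compound 4, and only the group attached to it is exchanged. For the measured compounds named here, no measured step exchanges a six-membered aromatic ring of carbon only for a five-membered non-aromatic ring with 1 hetero atom, so no step bears directly on this change. The steps that vary the group on the amide-type nitrogen, a 26-fold lower number from compound 1 to compound 2 (1.42 log units; beyond the scatter) and an 8.1-fold lower number from compound 1 to compound 3 (0.91 log units; beyond the scatter), were large to modest, while the step of a 3.2-fold higher number from compound 2 to compound 3 (0.51 log units; beyond the scatter) that only swapped a substituent was modest. A change of this kind is therefore expected to move the number in this assay by at most a modest amount, with its direction uncertain, so that the expected step of a 1.7-fold lower number from compound 3 to compound 4 (0.23 log units; within the scatter) stays close to the scatter. Compound 4 is accordingly estimated at 50000 nM, within a range from 12000 nM to 200000 nM.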

Compound 4, half-maximal inhibitory concentration: 96000 nM
Beside the measured number, compound 4's estimate is 1.9-fold (0.28 log units) below it; the range from low to high includes it.
By their numbers in this assay, from the lowest: compound 2; then compounds 3 and 4 (each within the scatter of the next); then compound 1.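

In this assay, the group on the amide-type nitrogen can take on a five-membered non-aromatic ring with 1 hetero atom and 1 hydrogen-bond donor without a change beyond the scatter relative to the nitro-bearing group (a 1.1-fold higher number from compound 3 to compound 4 (0.06 log units; within the scatter)), so this position accepts more than a single six-membered aromatic ring of carbon only. Compound 4 also stays clearly under the diacylhydrazide compound 1 (a 7.1-fold lower number from compound 1 to compound 4 (0.85 log units; beyond the scatter)), which makes three hydrazones on that side of compound 1, yet the new group does not match the bromo compound (a 3.7-fold higher number from compound 2 to compound 4 (0.57 log units; beyond the scatter)), and compound 2 keeps the lowest number of the four. No measurement shown here gives a reason for these numbers.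

The compounds shown leave open whether an amine or a carboxylic acid on the aromatic ring of the hydrazone would fall under the number of compound 2, and whether a substituent on the benzene ring of the new group would shift compound 4 at all. They also leave open how much of the gap to compound 1 belongs to the hydrazone link itself, since that step also exchanges the attached group.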